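The source may report more compounds than this note shows. Statements on the series, on what has been measured and on what is new or still open speak of the compounds shown alone.

In a functional assay on cells (Cancer cell lines, Homo sapiens) for inhibition (a lower number here means a stronger inhibitor of growth, a higher number a weaker inhibitor of growth), compound 1 (`Nc1ccc(-c2nc3cc(F)ccc3s2)cc1`) gives 11500 nM, while compound 2 (`Nc1ccc(-c2nc3cc(F)ccc3s2)cc1I`) gives 70 nM, the lower of the two numbers. Compound 3 (`Nc1ccc(-c2nc3cc(F)ccc3s2)cc1Br`) differs from compound 2 by bromo in place of iodo on an aromatic carbon, which is bromo in place of iodo on an aromatic carbon. Among the compounds with values here, the one measured step at this carbon, a 160-fold lower number from compound 1 to compound 2 (2.22 log units; beyond the scatter), is large, so a swap of one halogen for another is expected to keep most of that gain. Within the data shown here, no measured compound carries bromo, so the size stays uncertain. The expected change is a 2.9-fold higher number from compound 2 to compound 3 (0.46 log units; beyond the scatter), a modest move towards weaker inhibition. For compound 3 the estimate is 200 nM, with an expected range of 40 nM to 2000 nM.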

Compound 3, concentration for 50% growth inhibition: 50 nM
Compound 3: the middle estimate sits 4.0-fold (0.60 log units) above what was measured; measured number inside the range.
By their numbers in this assay, from the lowest: compounds 3 and 2 (each within the scatter of the next); then compound 1.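

In this assay, the swap at this carbon gives a 1.4-fold lower number from compound 2 to compound 3 (0.15 log units; within the scatter), so bromo and iodo cannot be told apart here. With a 230-fold lower number from compound 1 to compound 3 (2.36 log units; beyond the scatter) for bromo in place of hydrogen, the large gain is no longer tied to iodo alone but is seen with two different halogens. Nothing available explains why a halogen on this carbon has so large an effect. On these data alone, whether chloro, a methyl group or a nitrile on the same carbon would keep the gain stays open. So does whether the gain would survive replacing the neighbouring amino group with a hydroxyl group.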